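The source may report more compounds than this note shows. Statements on the series, on what has been measured and on what is new or still open speak of the compounds shown alone.

Three amides of one shared core have been tested in an ADME assay on MRC5 cells (Homo sapiens) for inhibition, with a stated time of 72 h; on this read-out higher numbers stand for an effect only at larger amounts of compound and lower numbers for an effect already at smaller amounts. Compound 1 `COc1cccc(OC)c1C(=O)Nc1c[nH]nc1C(=O)N[C@H]1CC[C@H](OC)CC1`, with 4-methoxycyclohexyl on the amide-type nitrogen, gives 31000 nM. Compound 2 `COc1cccc(OC)c1C(=O)Nc1c[nH]nc1C(=O)NN1CCOCC1`, with morpholin-4-yl there, reaches only a limit, > 50000 nM. Compound 3 `CCCCCNC(=O)c1n[nH]cc1NC(=O)c1c(OC)cccc1OC`, with pentyl there, also reaches only a limit, > 50000 nM. Compound 3 thus stands at the limit of > 50000 nM in this assay, at which 2 of the 3 values shown sit.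

Compound 4 `COc1cccc(OC)c1C(=O)Nc1c[nH]nc1C(=O)Nc1ccccc1` has not yet been measured. It differs from compound 3 as follows: phenyl in place of pentyl on an amide-type nitrogen. In words, phenyl takes the place of pentyl on an amide-type nitrogen.

For the measured compounds named here, three measured steps bear on this change, all made on that same nitrogen. Pentyl in place of 4-methoxycyclohexyl gave an at least 1.6-fold higher number from compound 1 to compound 3 (0.20 log units; that floor lies within the scatter). Morpholin-4-yl in place of 4-methoxycyclohexyl gave an at least 1.6-fold higher number from compound 1 to compound 2 (0.20 log units; that floor lies within the scatter). Pentyl in place of morpholin-4-yl gave a step that the two limits leave unreadable from compound 2 to compound 3. None of these steps is shown to exceed the scatter, and no measured compound carries phenyl at this nitrogen.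

Going by the values given here, the only actual number, 31000 nM for compound 1, anchors the lower side of the expectation. In this assay, no step beyond the scatter is therefore expected, and the estimated step is an at least 1.2-fold lower number from compound 3 to compound 4 (0.09 log units; that floor lies within the scatter). For compound 4 the estimated value is 40000 nM, with an expected range of 15000 nM to 50000 nM.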

Compound 4, half-maximal effective concentration: > 50000 nM
Compound 4 was reported as a limit; the forecaster's own chance of this, stated with the estimate: 55%; at least 1.2-fold (0.09 log units) between middle value and limit.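

Phenyl, a six-membered aromatic ring of carbon only, now sits on the amide-type nitrogen, and in this assay compound 4 gives only a limit, > 50000 nM. An aromatic ring at this place therefore adds no measurable value, and the open-chain pentyl and the morpholin-4-yl group are now joined at the same limit by a third kind of group: the limit of > 50000 nM in this assay, at which 3 of the 4 values shown sit. Phenyl in place of 4-methoxycyclohexyl gives an at least 1.6-fold higher number from compound 1 to compound 4 (0.20 log units; that floor lies within the scatter), while the steps among the three compounds that carry limits cannot be read.

Going by these compounds, how compound 2, compound 3 and compound 4 rank against one another stays open, as does whether 4-methoxycyclohexyl truly differs from the other groups, since every readable step from it has a floor within the scatter. Also open, on these data alone, is what a plain cyclohexyl, a benzyl or a phenyl bearing a methoxy group on this same nitrogen would give in this assay, and whether any such group would yield a number rather than a limit.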